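Dichlorophenyl in place of dimethoxyphenyl: working notes

The compounds below may be only part of what the source reports. "The series", "measured", "known", "first", "only" and "open" are said of these compounds alone.

Within the data shown here, in a functional assay on IGROV-1 cells (Homo sapiens) for inhibition, read by sulforhodamine B assay, with a stated time of 48 h (on this read-out lower numbers stand for stronger inhibition of growth and higher numbers for weaker inhibition of growth), compound 1 `O=C(Cc1csc2nc(-c3ccc(Br)cc3)cn12)N/N=C/c1ccc(O)cc1` gives 10700 nM and compound 2 `COc1cccc(OC)c1/C=N/NC(=O)Cc1csc2nc(-c3ccc(Br)cc3)cn12` gives 3980 nM, the lower of the two numbers so far. Next is compound 3 `O=C(Cc1csc2nc(-c3ccc(Br)cc3)cn12)N/N=C/c1ccc(Cl)cc1Cl`, with 2,4-dichlorophenyl in place of 2,6-dimethoxyphenyl on a carbon with a double bond to nitrogen. Among the measured compounds shown here, one measured step bears on this place, a 2.7-fold lower number from compound 1 to compound 2 (0.43 log units; beyond the scatter), and it is modest. For the measured compounds named here, with only this step as a guide, no change beyond the scatter is expected in this assay. The expected step is a 1.3-fold higher number from compound 2 to compound 3 (0.10 log units; within the scatter). For compound 3 the estimated value is 5000 nM, with an expected range of 1800 nM to 13000 nM.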

Compound 3, concentration for 50% growth inhibition: 15800 nM
Estimate against measurement, compound 3: 3.2-fold (0.50 log units) below; measured number above the stated range.
By their numbers in this assay, from the lowest: compound 2; then compounds 1 and 3 (each within the scatter of the next).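

In this assay, 2,4-dichlorophenyl on a carbon with a double bond to nitrogen does not keep the gain seen with 2,6-dimethoxyphenyl (a 4.0-fold higher number from compound 2 to compound 3 (0.60 log units; beyond the scatter)), and its difference from 4-hydroxyphenyl stays within the scatter (a 1.5-fold higher number from compound 1 to compound 3 (0.17 log units; within the scatter)). Among these three groups, only 2,6-dimethoxyphenyl stands apart, with compound 2 the strongest of the set. No available evidence accounts for this result.

On these data alone, it remains open whether the lower number depends on having both methoxy groups or on where they sit. How a dimethylamino group or a carboxylic acid on this phenyl ring would read is also unresolved.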